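Aryl variation on the triazole in the antiproliferative series

This account rests on a few compounds, and the source may have more. Where it says the series, first, only, none or still open, it means among the compounds named here.

Measured so far in a functional assay on A549 cells (Homo sapiens) for antiproliferative activity, read by MTT assay, with a stated time of 48 h; on this read-out higher numbers stand for weaker inhibition and lower numbers for stronger inhibition:
Compound 1 `N#CC1=C(N)Oc2c(N)cc3nc4ccccc4nc3c2C12C(=O)N(Cc1cnnn1-c1cccc(C(F)(F)F)c1)c1ccccc12` gives 5400 nM.
Compound 2 `N#CC1=C(N)Oc2c(N)cc3nc4ccccc4nc3c2C12C(=O)N(Cc1cnnn1-c1c(F)cccc1F)c1ccccc12` gives only a limit of the assay, > 50000 nM.

Compound 2 thus stands at the upper edge of the numbers seen: its value in this assay is a limit, not a number, and it is the one entry sitting at the limit of > 50000 nM in this assay, at which 1 of the 2 values shown sits. Going by the values given here, the step of an at least 9.2-fold higher number from compound 1 to compound 2 (0.96 log units; beyond the scatter) is the only measured change on this aromatic nitrogen, and it runs toward weaker inhibition.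

Compound 3 `N#CC1=C(N)Oc2c(N)cc3nc4ccccc4nc3c2C12C(=O)N(Cc1cnnn1-c1c(Cl)cc(Cl)cc1Cl)c1ccccc12` differs from compound 2 by 2,4,6-trichlorophenyl in place of 2,6-difluorophenyl on an aromatic nitrogen. Among the compounds with values here, no measured step covers this exchange; the only one that bears on the aryl group at this position is an at least 9.2-fold higher number from compound 1 to compound 2 (0.96 log units; beyond the scatter), which was at least modest and left compound 2 at the limit. The expected step of an at least 1.1-fold lower number from compound 2 to compound 3 (0.04 log units; that floor lies within the scatter) is therefore taken as none beyond the scatter, with a wide range kept since the starting value is itself a limit. Compound 3 is estimated at 45000 nM (range 12000 nM to 150000 nM), with a fair chance that this assay again reports only a limit.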

Compound 3, half-maximal inhibitory concentration: > 50000 nM
Compound 3 ended at the assay's limit; the forecaster's own chance of this, stated with the estimate: 55%; at least 1.1-fold (0.04 log units) between middle value and limit.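

In this assay compound 3 gives > 50000 nM, which is a limit of the assay and not a number. Putting 2,4,6-trichlorophenyl in place of 3-(trifluoromethyl)phenyl on the aromatic nitrogen gives an at least 9.2-fold higher number from compound 1 to compound 3 (0.96 log units; beyond the scatter), so a second aryl group now ends on the side of weaker inhibition, this time one carrying chlorine instead of fluorine. The step between the two limits cannot be read, which leaves 2,6-difluorophenyl and 2,4,6-trichlorophenyl unordered, and compound 1 remains the only readable value at this position: the limit of > 50000 nM in this assay, at which 2 of the 3 values shown sit.

It remains open whether the difference from compound 1 follows the trifluoromethyl group itself or the halogen patterns of 2,6-difluorophenyl and 2,4,6-trichlorophenyl, since the compounds shown change both together. An unsubstituted phenyl, a 4-methoxyphenyl or a phenyl bearing an amine would show whether any aryl group other than 3-(trifluoromethyl)phenyl gives a readable number here.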